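Swapping the aryl group on the carbonyl: expected tolerance

This account rests on a few compounds, and the source may have more. Where it says the series, first, only, none or still open, it means among the compounds named here.

Compound 1 `Cc1ccccc1C(=O)N(C(=S)OCCN1C(=O)c2ccccc2C1=O)c1ccc(Cl)cc1` is one of three measured analogues sharing a core. In an ADME assay on MT4 cells (Homo sapiens) for cytotoxicity, read by MTT assay (a higher number here means that more compound is tolerated, a lower number that less compound is tolerated), compound 1 gives 21000 nM, level with compound 2 `O=C1c2ccccc2C(=O)N1CCOC(=S)N(C(=O)c1ccccc1[N+](=O)[O-])c1ccc(Cl)cc1` at 21000 nM, the two together being the lowest of the three numbers; compound 3 `O=C1c2ccccc2C(=O)N1CCOC(=S)N(C(=O)c1c(F)cccc1F)c1ccc(Cl)cc1` gives 39000 nM. The steps are small: no change at the digits printed from compound 1 to compound 2 (within the scatter), a 1.9-fold higher number from compound 1 to compound 3 (0.27 log units; within the scatter) and a 1.9-fold higher number from compound 2 to compound 3 (0.27 log units; within the scatter). Compound 4 `O=C1c2ccccc2C(=O)N1CCOC(=S)N(C(=O)c1ccc(Cl)cc1Cl)c1ccc(Cl)cc1` has not been measured. It differs from compound 1 as follows: 2,4-dichlorophenyl in place of 2-methylphenyl on a carbonyl carbon. Among the compounds with values here, the steps that bear on this change are those on the carbonyl carbon, from compound 1 to compound 3 and from compound 2 to compound 3, each within the scatter, so no step beyond the scatter is expected here either. For compound 4 the expected value is 25000 nM, with a range from 12000 nM to 50000 nM, which means an expected step of a 1.2-fold higher number from compound 1 to compound 4 (0.08 log units; within the scatter).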

Compound 4, half-maximal cytotoxic concentration: 18000 nM
The estimate for compound 4 lay 1.4-fold (0.14 log units) above the measured number, and the stated range covers the measured number.
By their numbers in this assay, from the lowest: compounds 4, 1, 2 and 3 (each within the scatter of the next, the first and the last beyond it).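

At this carbonyl carbon, swapping one aryl group for another now gives a step beyond the scatter in this assay, though a modest one: a 2.2-fold lower number from compound 3 to compound 4 (0.34 log units; beyond the scatter), the first such step among these compounds. The other two steps, a 1.2-fold lower number from compound 1 to compound 4 (0.07 log units; within the scatter) and a 1.2-fold lower number from compound 2 to compound 4 (0.07 log units; within the scatter), do not separate 2,4-dichlorophenyl from 2-methylphenyl or 2-nitrophenyl. Within the data shown here, nothing available explains the one step beyond the scatter. On these data alone, what a phenyl ring carrying an amine or a carboxylic acid would give at this carbonyl carbon stays open.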